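Thiosemicarbazide series: methyl on the aryl ring

The compounds below may be only part of what the source reports. "The series", "measured", "known", "first", "only" and "open" are said of these compounds alone.

Compound 1 `COc1cc(C(=O)NNC(=S)Nc2csc(-c3ccc(C)cc3)c2)cc(OC)c1OC` — in a functional assay on A549 cells (Homo sapiens) for inhibition, read by colorimetric assay and MTT assay, with a stated time of 72 h (on this read-out higher numbers stand for weaker inhibition and lower numbers for stronger inhibition), compound 1 gives 39000 nM
Compound 2 `COc1ccc(C(=O)NNC(=S)Nc2csc(-c3ccccc3)c2)cc1OC` — in this assay compound 2 gives 20000 nM

Compound 2 holds the lower of the two numbers, but its gap to compound 1 lies within the scatter, so no order between them is drawn. Compound 3 `COc1ccc(C(=O)NNC(=S)Nc2csc(-c3ccc(C)cc3)c2)cc1OC` differs from compound 2 by methyl in place of hydrogen on an aromatic carbon. Among the compounds with values here, no measured pair isolates this change; compound 1 carries the same 4-methylphenyl yet also differs in its methoxy pattern. The step of a 1.3-fold higher number from compound 2 to compound 3 (0.10 log units; within the scatter) is expected to be small, none beyond the scatter. Compound 3 is estimated at 25000 nM, within 10000 nM to 60000 nM.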

Compound 3, half-maximal inhibitory concentration: 36000 nM
Compound 3: the middle estimate sits 1.4-fold (0.16 log units) below what was measured; the measured number falls inside the stated range.
By their numbers in this assay, from the lowest: compounds 2, 3 and 1 (each within the scatter of the next).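

In this assay the methyl para to a large group now has a pair that differs in one place: the step of a 1.8-fold higher number from compound 2 to compound 3 (0.26 log units; within the scatter) stays within the scatter, so phenyl and 4-methylphenyl cannot be told apart here. The step of a 1.1-fold lower number from compound 1 to compound 3 (0.03 log units; within the scatter) also stays within the scatter, so hydrogen in place of methoxy on an aromatic carbon gives no order either. No evidence on the size of these steps is available.

Still open, on these data alone, is whether an amine, a carboxylic acid or a longer chain in place of this methyl would give a step beyond the scatter.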